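A few compounds are considered here, and "the series" means these few. Any claim that something is new, unique, unknown or untested is made for them only; others in the source may bear on it.

Series notes. The shared core is constant; the variable point is one aromatic carbon, carrying ethyl in compound 1 `CCc1cc(C)c(C(=O)N=C(N)N)cc1S(C)(=O)=O`, pentyl in compound 2 `CCCCCc1cc(C)c(C(=O)N=C(N)N)cc1S(C)(=O)=O` and methylsulfanyl in compound 3 `CSc1cc(C)c(C(=O)N=C(N)N)cc1S(C)(=O)=O`. In a functional assay for inhibition of sodium/hydrogen exchanger (Oryctolagus cuniculus) (a higher number here means a weaker inhibitor, a lower number a stronger inhibitor), compound 1 gives 4.8 nM, compound 2 gives 27 nM and compound 3 gives 6 nM. Compound 3 stands second highest of the three numbers: its nearest neighbour is compound 1, within the scatter, and its furthest is compound 2, with a 4.5-fold lower number from compound 2 to compound 3 (0.65 log units; beyond the scatter).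

Compound 4 `CCCSc1cc(C)c(C(=O)N=C(N)N)cc1S(C)(=O)=O` differs from compound 3 by ethyl in place of hydrogen on a saturated chain carbon bound to a sulfur. The measured step that bears on this is the chain extension a 5.6-fold higher number from compound 1 to compound 2 (0.75 log units; beyond the scatter), where the longer chain on this position gave a weaker inhibitor, and a 4.5-fold lower number from compound 2 to compound 3 (0.65 log units; beyond the scatter) points the same way. The extension here is shorter than the propyl added in that step, so a smaller loss is expected: the expected step is a 2.5-fold higher number from compound 3 to compound 4 (0.40 log units; beyond the scatter). Compound 4 is therefore estimated in this assay at 15 nM, with a range of 6 nM to 40 nM.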

Compound 4, half-maximal inhibitory concentration: 6.8 nM
Compound 4: middle estimate off by 2.2-fold (0.34 log units), on the high side; measured number inside the range.
By their numbers in this assay, from the lowest: compounds 1, 3 and 4 (each within the scatter of the next); then compound 2.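

In this assay, going from methylsulfanyl to propylsulfanyl on this aromatic carbon stays within the scatter (a 1.1-fold higher number from compound 3 to compound 4 (0.05 log units; within the scatter)), so the loss seen on going from ethyl to pentyl does not reappear with this chain extension on sulfur. Propylsulfanyl also stays within the scatter of ethyl (a 1.4-fold higher number from compound 1 to compound 4 (0.15 log units; within the scatter)), whereas replacing pentyl with propylsulfanyl gives a step beyond the scatter (a 4.0-fold lower number from compound 2 to compound 4 (0.60 log units; beyond the scatter)), leaving compound 2 as the only one of the four set apart. No measurement shown here explains why the extension on sulfur and the extension on the carbon chain differ.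

On these data alone, whether a longer chain on sulfur, such as pentylsulfanyl, would stay within the scatter of compound 3 or move towards compound 2 remains open. As far as these compounds go, the outcome with an amine or a carboxylic acid on this aromatic carbon is also open.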